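Swapping the aryl hydrazone in a thiosemicarbazide series

The source may hold more compounds than are shown below. What is called first, only, known or untested is meant among the compounds shown, and "the series" means these compounds.

Measured so far in a functional assay on MCF7 cells (Homo sapiens) for cytotoxicity, read by sulforhodamine B assay; on this read-out higher numbers stand for weaker inhibition of growth and lower numbers for stronger inhibition of growth:
- compound 1, `CC1=CC[C@@H]([C@@](C)(O)CCCC(C)(C)NC(=S)NN)CC1`: 84200 nM
- compound 2, `CC1=CC[C@@H]([C@@](C)(O)CCCC(C)(C)NC(=S)N/N=C\c2ccc(O)cc2)CC1`: 21200 nM
- compound 3, `CC1=CC[C@@H]([C@@](C)(O)CCCC(C)(C)NC(=S)N/N=C\c2cccc(Cl)c2)CC1`: 19500 nM

Compound 3 gives the lowest number of the three, but its gap to compound 2 is within the scatter, so the two cannot be told apart; only the parent compound 1 stands clearly higher, as seen in a 4.3-fold lower number from compound 1 to compound 3 (0.64 log units; beyond the scatter) and a 4.0-fold lower number from compound 1 to compound 2 (0.60 log units; beyond the scatter). The step to compound 4, `CC1=CC[C@@H]([C@@](C)(O)CCCC(C)(C)NC(=S)N/N=C(/C)c2ccccc2)CC1`, is a group of 9 heavy atoms (8 carbon, 1 nitrogen; one six-membered aromatic ring of carbon only) in place of a group of 9 heavy atoms (7 carbon, 1 nitrogen, 1 chlorine; one six-membered aromatic ring of carbon only), on an amide-type nitrogen. Going by the values given here, the one measured step that bears on it is a 1.1-fold lower number from compound 2 to compound 3 (0.04 log units; within the scatter), where one aromatic substituent was exchanged for another and the number hardly moved. Compound 4 keeps the aromatic hydrazone, which is the feature that separates compounds 2 and 3 from compound 1, so compound 4 is expected to stay close to compound 3, with a 1.0-fold higher number from compound 3 to compound 4 (0.01 log units; within the scatter) as the estimated step. For compound 4 the expected value in this assay is 20000 nM, within a range from 8000 nM to 50000 nM.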

Compound 4, concentration for total growth inhibition: 62900 nM
For compound 4 the middle estimate is 3.1-fold (0.50 log units) below the measured one, outside the stated range (above it).
By their numbers in this assay, from the lowest: compounds 3 and 2 (each within the scatter of the next); then compounds 4 and 1 (each within the scatter of the next).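

In this assay an aromatic ring and a double bond on the amide-type nitrogen are not enough on their own to hold the lower numbers, since compound 4 has both and there is still a 3.2-fold higher number from compound 3 to compound 4 (0.51 log units; beyond the scatter) and a 3.0-fold higher number from compound 2 to compound 4 (0.47 log units; beyond the scatter). Compound 4 also cannot be told apart from the parent, with only a 1.3-fold lower number from compound 1 to compound 4 (0.13 log units; within the scatter), so the group it carries does not share the clear separation from compound 1 seen with the other two hydrazones. Nothing available explains why this group behaves differently.

Compound 4 differs from compounds 2 and 3 both in its extra methyl group and in its ring having no hydroxyl or chlorine, so the two changes remain tangled. A plain phenyl hydrazone without that methyl, or a 3-chlorophenyl hydrazone with it, would separate them.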